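Pyridin-2-yl for methylfuranyl on the shared core

The compounds below may be only part of what the source reports. "The series", "measured", "known", "first", "only" and "open" are said of these compounds alone.

Three members of the series have numbers in a functional assay on HeLa cells (Homo sapiens) for cytotoxicity, in the presence of a further agent that is not named here; a lower number here means a stronger inhibitor, a higher number a weaker inhibitor. Compound 1 `Clc1ccc(-c2cc(-c3cccs3)nc(-c3ccccc3Cl)c2)o1` gives 18500 nM in this assay. Compound 2 `Clc1ccc(-c2cc(-c3ccoc3)cc(-c3cccs3)n2)cc1` gives 5530 nM in this assay. Among the compounds with values here, compound 3 `Cc1ccc(-c2cc(-c3ccc(Cl)o3)cc(-c3ccsc3)n2)o1` returns only a limit, > 50000 nM, so its standing among the three rests on the fact that it is the one value at the edge of the assay the limit of > 50000 nM in this assay, at which 1 of the 3 values shown sits, rather than on a measured number. Within the data shown here, no pair of these three differs in one place, so no measured step is available.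

Compound 4 `Clc1ccc(-c2cc(-c3ccsc3)nc(-c3ccccn3)c2)o1` is not yet measured. It differs from compound 3 by pyridin-2-yl in place of 5-methylfuran-2-yl on an aromatic carbon. The change keeps the count of ring hetero atoms and of hydrogen-bond acceptors, and swaps a five-membered ring for a six-membered one at the position next to the ring nitrogen of the core.

With compound 3 known only as a limit, the expected step of an at least 2.0-fold lower number from compound 3 to compound 4 (0.30 log units; that floor lies within the scatter) cannot be fixed in size, and a value near or past the limit is nearly as plausible as a gain. Compound 4 is estimated at 25000 nM in this assay, within 6000 nM to 90000 nM.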

Compound 4, half-maximal inhibitory concentration: 22500 nM
Estimate against measurement, compound 4: 1.1-fold (0.05 log units) above; measured number inside the range.
By their numbers in this assay, from the lowest: compound 2; then compounds 1 and 4 (each within the scatter of the next). At a limit, above all of these: compound 3.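

Within the data shown here, on the aromatic carbon next to the ring nitrogen, pyridin-2-yl in place of 5-methylfuran-2-yl gives an at least 2.2-fold lower number from compound 3 to compound 4 (0.34 log units; beyond the scatter) in this assay as the one step that can be read so far. Compound 3 stands only at a limit (> 50000 nM) in this assay and no measured number exists for it. The two groups carry the same counts of heavy atoms and hydrogen-bond acceptors, so the step goes with the change of ring size and hetero atom, and its size is only a floor set by the limit: the limit of > 50000 nM in this assay, at which 1 of the 4 values shown sits.

Open, on these data alone, is whether an amine, a carboxylic acid or a longer alkyl chain at this position would move the number further. Also open, as far as these compounds go, is how pyridin-2-yl behaves with the other groups of compound 1 or compound 2 on the shared core.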